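The compounds below may be only part of what the source reports. "The series", "measured", "known", "first", "only" and "open" are said of these compounds alone.

Measured in an ADME assay on microsomes from liver (Mus musculus, strain CD1) for metabolic stability; a lower number here means that the compound disappears faster, a higher number that the compound lasts longer:
- compound 1 `COc1cc(N2C(=O)C3(CCC3)N(c3ccc(OC4CCN(C)CC4)nc3)C2=S)cnc1C#N` (2.25 h)
- compound 2 `CN1CCC(Oc2ccc(N3C(=S)N(c4cnc(C#N)c(C(F)(F)F)c4)C(=O)C34CCC4)cc2)CC1` (1.55 h)

Compound 1 and compound 2 lie within the scatter of each other, so these two numbers do not separate them. The core of compound 1 carries a 6-cyano-5-methoxypyridin-3-yl group. Compound 3 `CN1CCC(Oc2ccc(N3C(=S)N(c4cnc(C#N)c(C(F)(F)F)c4)C(=O)C34CCC4)cn2)CC1`, not yet measured, has a 6-cyano-5-(trifluoromethyl)pyridin-3-yl group there instead: trifluoromethyl in place of methoxy on an aromatic carbon. Among the measured compounds shown here, no pair of measured compounds shows this change on its own, so there is no direct step to carry over. The nearest guide is compound 2, which also carries trifluoromethyl and gives (1.55 h), within the scatter of compound 1. On that basis, no step beyond the scatter is expected in this assay, and no direction is favoured. The estimated change is a 1.1-fold lower number from compound 1 to compound 3 (0.05 log units; within the scatter) and remains uncertain. For compound 3 the expected half-life is 2 h (estimated range 1 h to 4 h).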

Compound 3, half-life: 2.88 h
Estimate against measurement, compound 3: 1.4-fold (0.16 log units) below; measured number inside the range.
By their numbers in this assay, from the lowest: compounds 2, 1 and 3 (each within the scatter of the next).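

The change from methoxy to trifluoromethyl, on an aromatic carbon ortho to a cyano group and two atoms from the ring nitrogen, can now be read directly in this assay as a 1.3-fold higher number from compound 1 to compound 3 (0.11 log units; within the scatter) in a pair that differs in this one place. At this position, then, the swap leaves the half-life unresolved from compound 1 to compound 3, even though trifluoromethyl has more heavy atoms than methoxy and, unlike it, no hydrogen-bond acceptor. Nothing in the available data accounts for this result.

The compounds shown hold only these two groups at this position, so the reading of this assay for a chlorine atom, an ethoxy group or an amine there remains open. Among the compounds shown here, also open is whether the same swap would give a similar reading with other groups elsewhere on the shared core, since this single pair is the only direct comparison for this change.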